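The source may hold more compounds than are shown below. What is called first, only, known or untested is meant among the compounds shown, and "the series" means these compounds.

Working notes on the series. Compound 1 `O=C(O)c1csc([C@H]2CC[C@@H]3[C@@H](COc4ccc(C(F)(F)F)cc4)[C@H](O)C[C@@H]3O2)n1` gives 13 nM in a functional assay on CHO cells for agonist activity at prostaglandin E2 receptor EP2 subtype (Homo sapiens), read by HTRF and cAMP accumulation, with a stated time of 30 min; a lower number here means that less compound is needed, a higher number that more compound is needed for the effect. Compound 2 `O=C(O)c1csc([C@H]2CC[C@@H]3[C@@H](/C=C/CCCOc4ccccc4)[C@H](O)C[C@@H]3O2)n1` gives 13 nM in this assay, so compound 1 and compound 2 stand level, together the lowest of the three numbers. Compound 3 `O=C(O)CCC[C@H]1CC[C@@H]2[C@@H](/C=C/[C@@H](O)COc3ccccc3)[C@H](O)C[C@@H]2O1` gives 8900 nM in this assay, a much higher number than compound 1 and well beyond the scatter.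

Compound 4 `O=C(O)c1csc([C@H]2CC[C@@H]3[C@@H](COc4ccccc4C(F)(F)F)[C@H](O)C[C@@H]3O2)n1` differs from compound 1 by 2-(trifluoromethyl)phenyl in place of 4-(trifluoromethyl)phenyl on an oxygen on a saturated carbon, the same atoms joined differently. Among the measured compounds shown here, no measured pair shows such a change, so no step size can be read off. Compound 4 is expected to stay close to compound 1, within a small step of a 1.9-fold higher number from compound 1 to compound 4 (0.28 log units; within the scatter), and its estimated value in this assay is 25 nM with a range from 5 nM to 150 nM.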

Compound 4, half-maximal effective concentration: 0.5 nM
Compound 4: middle estimate off by 50-fold (1.70 log units), on the high side; the measured number lies below the stated range.
By their numbers in this assay, from the lowest: compound 4; then compounds 1 and 2 (each within the scatter of the next); then compound 3.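

In this assay, 2-(trifluoromethyl)phenyl in place of 4-(trifluoromethyl)phenyl on an oxygen on a saturated carbon gives a 26-fold lower number from compound 1 to compound 4 (1.41 log units; beyond the scatter) and so shows that this position responds strongly to where the trifluoromethyl group sits, with the atoms unchanged. Among the compounds shown here, the earlier compounds offered no pair differing in one place, so this is the first step that can be read. Nothing available accounts for its size.

Open, as far as these compounds go, is whether a chlorine or a methoxy group in place of the trifluoromethyl of compound 4 holds this level, and whether 2-(trifluoromethyl)phenyl gives a similar step on the longer chain of compound 2.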